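Adding a Second Fluorine to the Benzyl Ring

This account rests on a few compounds, and the source may have more. Where it says the series, first, only, none or still open, it means among the compounds named here.

Compound 2 `Cn1c(=O)c2[nH]c(-c3ccc(S(=O)(=O)N4CCN(Cc5ccc(F)cc5)CC4)cc3)cc2n(C)c1=O` gives 10 nM in an assay on HEK293 cells for displacement of a labelled ligand from adenosine receptor A2b (Homo sapiens) (a lower number here means a stronger inhibitor, a higher number a weaker inhibitor), the higher of the two numbers shown, while compound 1 `Cn1c(=O)c2[nH]c(-c3ccc(S(=O)(=O)N4CCN(Cc5ccc(Br)cc5)CC4)cc3)cc2n(C)c1=O` gives 1 nM in this assay. Going by the values given here, the single measured step, a 10-fold higher number from compound 1 to compound 2 (1.00 log units; beyond the scatter), exchanges one halogen for another and so does not test an added fluoro. Compound 3 `Cn1c(=O)c2[nH]c(-c3ccc(S(=O)(=O)N4CCN(Cc5ccc(F)cc5F)CC4)cc3)cc2n(C)c1=O` carries fluoro in place of hydrogen on an aromatic carbon. Among the compounds with values here, with no measured step of the same kind, only a small change is expected, no change at the digits printed from compound 2 to compound 3 (within the scatter), with neither direction favoured. Compound 3 is therefore estimated at 10 nM, within a range of 3 nM to 30 nM.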

Compound 3, half-maximal inhibitory concentration: 7 nM
Beside the measured number, compound 3's estimate is 1.4-fold (0.15 log units) above it; the measured number falls inside the stated range.
By their numbers in this assay, from the lowest: compound 1; then compounds 3 and 2 (each within the scatter of the next).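

In this assay, the fluoro added on the aromatic carbon ortho to a large group gives a 1.4-fold lower number from compound 2 to compound 3 (0.15 log units; within the scatter) and so shows that this position takes a fluoro without a readable shift. Putting 2,4-difluorophenyl in place of 4-bromophenyl leaves a 7.0-fold higher number from compound 1 to compound 3 (0.85 log units; beyond the scatter) and so the added fluoro does not close the gap to the bromo compound. Nothing shown accounts for either step. Going by these compounds, whether a chloro, a methyl or a methoxy group on that same carbon would also leave the number unmoved stays open.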